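A few compounds are considered here, and "the series" means these few. Any claim that something is new, unique, unknown or untested is made for them only; others in the source may bear on it.

Compound 2 `CC(C)Oc1cc(-c2cncc(-c3cnn(C)c3)c2)ccc1C(N)=O` gives the lowest of the two numbers recorded so far in an assay on HeLa cells for inhibition of MAP kinase-interacting serine/threonine-protein kinase 1/2 (Homo sapiens), read by AlphaScreen, with a stated time of 2 h (a lower number here means a stronger inhibitor, a higher number a weaker inhibitor), giving 750 nM. Its nearest neighbour is compound 1 `CC(C)Oc1cc(-c2cncc(-c3cnn(C(C)C)c3)c2)ccc1C(N)=O`, and in this assay compound 1 gives 940 nM; the step from one to the other was a 1.3-fold lower number from compound 1 to compound 2 (0.10 log units; within the scatter). Compound 3 `CC(C)Oc1cc(-c2cncc(-c3cnn(C4CCOC4)c3)c2)ccc1C(N)=O` is the next compound in this series, not yet measured in this assay. It differs from compound 2 in one place: oxolan-3-yl in place of methyl on an aromatic nitrogen. Among the measured compounds shown here, the only measured step that bears on this position is the one between compound 1 and compound 2, which exchanged isopropyl for methyl on the same aromatic nitrogen and was within the scatter. On that evidence the size of the group on that nitrogen has so far made little difference, so compound 3 is expected to show no step beyond the scatter, a 1.1-fold higher number from compound 2 to compound 3 (0.03 log units; within the scatter). Compound 3 is therefore estimated at 800 nM in this assay, with a range from 350 nM to 1800 nM.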

Compound 3, half-maximal inhibitory concentration: 390 nM
Beside the measured number, compound 3's estimate is 2.1-fold (0.31 log units) above it; the measured number falls inside the stated range.
By their numbers in this assay, from the lowest: compounds 3, 2 and 1 (each within the scatter of the next, the first and the last beyond it).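

With oxolan-3-yl on the aromatic nitrogen, the step from methyl stays within the scatter in this assay (a 1.9-fold lower number from compound 2 to compound 3 (0.28 log units; within the scatter)), but the step from isopropyl passes beyond it, if only modestly (a 2.4-fold lower number from compound 1 to compound 3 (0.38 log units; beyond the scatter)). Among the compounds shown here, this is the first step at this position to exceed the scatter, so the group on this nitrogen can matter, which the exchange of isopropyl for methyl alone did not show. No evidence is available that accounts for this step.

Going by these compounds, it remains open whether the oxygen of the ring matters or the ring alone does, a question that cyclopentyl, the same ring with only carbon atoms, could separate. Also open, on these data alone, is how an amine such as piperidin-4-yl, or the larger oxan-4-yl ring, would read on the same nitrogen.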